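A few compounds are considered here, and "the series" means these few. Any claim that something is new, unique, unknown or untested is made for them only; others in the source may bear on it.

Compound 1 `CC(C)(C)c1ccc(OCCCON2C(N)=NC(N)=NC23CCSCC3)cc1`: 1 nM
Compound 2 `NC1=NC2(CCOCC2)N(OCCCOc2ccc(Cl)cc2)C(N)=N1`: 360 nM
Compound 3 `NC1=NC2(CCSCC2)N(OCCCOc2cccc(Cl)c2Cl)C(N)=N1`: 1 nM

All three numbers come from a functional assay on A549 cells (Homo sapiens) for antiproliferative activity, read by MTT assay, with a stated time of 72 h; on this read-out lower numbers stand for stronger inhibition and higher numbers for weaker inhibition. Among them compound 2 stands highest at 360 nM, which marks the weakest inhibition of the set and lies well beyond the scatter from both compound 1 and compound 3. Compound 2 differs from those two in its core and also in its aromatic end group, so these numbers cannot separate the two differences.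

Compound 4 `NC1=NC2(CCOCC2)N(OCCCOc2ccccc2Br)C(N)=N1` keeps the core of compound 2 and changes only the end group: 2-bromophenyl in place of 4-chlorophenyl on an oxygen on a saturated carbon. For the measured compounds named here, no measured pair shows a swap of this kind, so the size of the step is uncertain. Compound 3 at 1 nM shows that another halogen-bearing ring can go with a low number, though on a different core. A modest move to lower numbers in this assay is therefore expected, with no change beyond the scatter also possible. The expected step of a 2.4-fold lower number from compound 2 to compound 4 (0.38 log units; beyond the scatter) is only a rough estimate. For compound 4 the estimated value is 150 nM, with an expected range from 20 nM to 800 nM.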

Compound 4, half-maximal inhibitory concentration: 160 nM
Compound 4: middle estimate off by 1.1-fold (0.03 log units), on the low side, and the stated range covers the measured number.
By their numbers in this assay, from the lowest: compounds 1 and 3 (each within the scatter of the next); then compound 4; then compound 2.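

For the compounds shown here, with the core held fixed, this is the first step in this assay that isolates the end group on the oxygen on a saturated carbon: 2-bromophenyl in place of 4-chlorophenyl gives a 2.3-fold lower number from compound 2 to compound 4 (0.35 log units; beyond the scatter). The step is modest but beyond the scatter, so on this core a change in the end group alone is enough to shift the number. Because the swap changes both the halogen and its place on the ring, the step cannot be assigned to either change alone, and no measurement available here explains it.

On these data alone, it remains open whether the same swap would give a step of similar size on the core of compound 3. It is also unknown how the number would respond if a methoxy group or an amine replaced the halogen, or if a longer chain carried the ring.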